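Efficacy notes on a phenoxybenzylamine acid series

The source may hold more compounds than are shown below. What is called first, only, known or untested is meant among the compounds shown, and "the series" means these compounds.

Measured compounds:
compound 1, `CC(Cc1ccc(NCc2cccc(Oc3ccccc3)c2)cc1)C(=O)O`, 70% in a functional assay on CHO cells for agonist activity at Free fatty acid receptor 1 (Homo sapiens), read by a luciferase reporter; a lower number here means a smaller maximal response, a higher number a larger maximal response
compound 2, `CC(CC(=O)O)c1ccc(NCc2cccc(Oc3ccccc3)c2)cc1`, 83%
compound 3, `O=C(O)[C@@H]1C[C@H]1c1ccc(NCc2cccc(Oc3ccccc3)c2)cc1`, 64%

Compound 3 has the lowest maximal response of the three. One of its gaps is a number 6 percentage points lower from compound 1 to compound 3 (within the scatter) and lies within the scatter; the other is a number 19 percentage points lower from compound 2 to compound 3 (beyond the scatter) and lies beyond it, so only the latter counts as a real difference.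

Compound 4, `CC(C)NC(=O)CCc1ccc(NCc2cccc(Oc3ccccc3)c2)cc1`, is not yet measured. It differs from compound 3 in one place: 2-(isopropylcarbamoyl)ethyl in place of 2-carboxycyclopropyl on an aromatic carbon.

The measured steps all swap one acid-bearing chain for another on the same aromatic carbon; none removes the carboxylic acid itself. The steps that touch compound 3, a number 6 percentage points lower from compound 1 to compound 3 (within the scatter) and a number 19 percentage points lower from compound 2 to compound 3 (beyond the scatter), were within the scatter and modest. They tell little about an amide in place of the acid, so the expectation is loosely held. A downward step is estimated, a number 19 percentage points lower from compound 3 to compound 4 (beyond the scatter). For compound 4 the expected value in this assay is 45%, with a range from 15% to 75%.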

Compound 4, largest response reached (reported as percent of maximum), in percent of the reference or control that the assay uses: 66%
The estimate for compound 4 lay 21 percentage points below the measured number; measured number inside the range.
By their numbers in this assay, from the lowest: compounds 3, 4 and 1 (each within the scatter of the next); then compound 2.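

In this assay, within the data shown here, the earlier compounds all carried a carboxylic acid at this position; with 2-(isopropylcarbamoyl)ethyl on the aromatic carbon para to a large group, the result is a number 2 percentage points higher from compound 3 to compound 4 (within the scatter) and a number 4 percentage points lower from compound 1 to compound 4 (within the scatter), so a carboxylic acid is not required here for a response on the level of these two compounds. Only the comparison with the 1-(carboxymethyl)ethyl chain separates the amide from an acid, at a number 17 percentage points lower from compound 2 to compound 4 (beyond the scatter), and the acid in that chain is thus the one arrangement shown that stands apart. No measurement in hand explains this result.

The compounds shown leave open what the isopropyl group contributes, which a primary carboxamide or a dimethylamide at this place would test. Also open, as far as these compounds go, is whether an ester or a tetrazole would match the amide, and whether a methyl branch on the amide chain would close the gap to compound 2.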